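The source may report more compounds than this note shows. Statements on the series, on what has been measured and on what is new or still open speak of the compounds shown alone.

Compound 1 `Cc1ccc(-c2cc3nc(C)c(C(OC(C)(C)C)C(=O)O)c(-c4cc(F)c5c(c4C)CCCO5)n3n2)cc1`: 94%
Compound 2 `Cc1nc2cc(-c3ccc(OCc4ccccc4)cc3)nn2c(-c2cc(F)c3c(c2C)CCCO3)c1C(OC(C)(C)C)C(=O)O`: 79%
Compound 3 `Cc1nc2cc(-c3cccc(OCc4ccccc4)c3)nn2c(-c2cc(F)c3c(c2C)CCCO3)c1C(OC(C)(C)C)C(=O)O`: 83%

These values come from an ADME assay on microsomes from liver (Rattus norvegicus), read by LC-MS, using NADPH, with a stated time of 10 min, tested at 0.5 uM; on this read-out higher numbers stand for a more stable compound and lower numbers for a less stable compound. Compound 3, at 83%, stands level with compound 2 within the usual scatter and lower than compound 1 beyond it.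

Compound 4 `Cc1nc2cc(-c3cccc(Oc4ccccc4)c3)nn2c(-c2cc(F)c3c(c2C)CCCO3)c1C(OC(C)(C)C)C(=O)O` differs from compound 3 by one change: phenyl in place of benzyl on an oxygen on an aromatic ring. In other words, benzyloxy becomes phenoxy.

Among the measured compounds shown here, the only measured step touching this group is a number 15 percentage points lower from compound 1 to compound 2 (beyond the scatter), a modest step beyond the scatter in which benzyloxy replaced methyl. For the measured compounds named here, no measured pair compares benzyloxy with phenoxy directly. In this assay, no step beyond the scatter is therefore expected here. The estimated step is a number 1 percentage points higher from compound 3 to compound 4 (within the scatter). Compound 4 is expected at 84%, within an estimated range of 71% to 94%.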

Compound 4, percent of the compound remaining: 97%
Compound 4: middle estimate off by 13 percentage points, on the low side, outside the stated range (above it).
By their numbers in this assay, from the lowest: compounds 2 and 3 (each within the scatter of the next); then compounds 1 and 4 (each within the scatter of the next).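

In this assay, phenyl in place of benzyl on the oxygen gives a number 14 percentage points higher from compound 3 to compound 4 (beyond the scatter). So a change as small as benzyloxy to phenoxy can move this read-out, something the earlier compounds, which carry only benzyloxy or methyl here, could not show. No measurement shown gives a reason for this step.

On these data alone, whether phenoxy would give the same rise in the placement held by compound 2 stays open. So does whether an amine or a carboxylic acid on the phenoxy ring would keep this stability.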